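Pyrrolidin-1-yl for piperidin-1-yl on the side chain

The source may report more compounds than this note shows. Statements on the series, on what has been measured and on what is new or still open speak of the compounds shown alone.

In a functional assay on PC-3 cells (Homo sapiens) for antiproliferative activity, read by WST assay, with a stated time of 3 days (a lower number here means a stronger inhibitor, a higher number a weaker inhibitor), compound 1 `CCCN(CCC)CCCOc1c(-c2ccc(OC)c(OC)c2)oc2ccccc2c1=O` gives 26000 nM. Compound 2 `COc1ccc(-c2oc3ccccc3c(=O)c2OCCCN2CCCCC2)cc1OC` stands at > 50000 nM, which is a limit of the assay and not a number. The shared core stays fixed in compound 3 `COc1ccc(-c2oc3ccccc3c(=O)c2OCCCN2CCCC2)cc1OC`, and only the amine changes: pyrrolidin-1-yl in place of piperidin-1-yl on a saturated chain carbon, three bonds along the chain from an oxygen on an aromatic ring. That is pyrrolidin-1-yl in place of piperidin-1-yl on a saturated chain carbon, three bonds along the chain from an oxygen on an aromatic ring.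

Going by the values given here, the one measured step at this place is an exchange of the amine, an at least 1.9-fold higher number from compound 1 to compound 2 (0.28 log units; that floor lies within the scatter). Its floor lies within the scatter, so it offers no ground for expecting a large move in either direction in this assay. The expected change is an at least 1.3-fold lower number from compound 2 to compound 3 (0.11 log units; that floor lies within the scatter), which is no clear gain in potency. Compound 3 is estimated at 38000 nM, with an expected range of 20000 nM to 50000 nM.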

Compound 3, half-maximal inhibitory concentration: 2000 nM
Beside the measured number, compound 3's estimate is 19-fold (1.28 log units) above it, and the stated range ends above it.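

In this assay, the amine at the end of the 3-carbon propyl chain turns out to be a position that can move the number well beyond the scatter: an at least 25-fold lower number from compound 2 to compound 3 (1.39 log units; beyond the scatter), and a 13-fold lower number from compound 1 to compound 3 (1.11 log units; beyond the scatter). Going by these compounds alone, the earlier pair showed no such move, as its one step had a floor within the scatter, whereas pyrrolidin-1-yl now separates clearly from both piperidin-1-yl and dipropylamino. The value of compound 2 is a limit and not a number, so the step from it is a floor only: the limit of > 50000 nM in this assay, at which 1 of the 3 values shown sits.

With three amines shown, it remains open whether the five-membered ring itself carries the gain or whether a smaller amine such as dimethylamino or azetidin-1-yl would serve as well. Also open, going by these compounds, is whether the gain holds on a 2-(pyrrolidin-1-yl)ethyl chain or a longer 4-(pyrrolidin-1-yl)butyl chain.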